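Swapping an Acid Chain for a Chloropyridine: Cytotoxicity Outlook

This account rests on a few compounds, and the source may have more. Where it says the series, first, only, none or still open, it means among the compounds named here.

Of the compounds shown here, two sharing one core have been tested in an ADME assay on BEAS-2B cells (Homo sapiens) for cytotoxicity, read by MTT assay, with a stated time of 72 h; on this read-out higher numbers stand for weaker inhibition and lower numbers for stronger inhibition. Compound 1 `COc1ccc(OC)c(Nc2cc(Nc3ccc(F)cc3)ncn2)c1` gives 18000 nM, and compound 2 `O=C(O)CCC(=O)Nc1cc(Nc2ccc(Cl)cc2)ncn1` gives 19000 nM in this assay; the two numbers lie within the scatter of each other, so they cannot be told apart. Compound 3 `Clc1ccc(Nc2cc(Nc3cccc(Cl)n3)ncn2)cc1` has not been measured. It differs from compound 2 by 6-chloropyridin-2-yl in place of (2-carboxyethyl)carbonyl on a nitrogen on an aromatic ring. For the measured compounds named here, with no measured step to lean on, the step of a 1.6-fold lower number from compound 2 to compound 3 (0.20 log units; within the scatter) is expected to be small, pointing downward if anywhere, and it may well stay within the scatter. In this assay compound 3 is estimated at 12000 nM, with a range from 4000 nM to 35000 nM.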

Compound 3, half-maximal inhibitory concentration: 18100 nM
For compound 3 the middle estimate is 1.5-fold (0.18 log units) below the measured one; the measured number falls inside the stated range.
By their numbers in this assay, from the lowest: compounds 1, 3 and 2 (each within the scatter of the next).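

In this assay, replacing the open (2-carboxyethyl)carbonyl chain with the ring-bearing 6-chloropyridin-2-yl on this nitrogen gives a 1.0-fold lower number from compound 2 to compound 3 (0.02 log units; within the scatter). Two groups with no ring and one six-membered aromatic ring therefore cannot be told apart at this position, so this change leaves the read-out unresolved. Nothing available accounts for this result.

From the compounds shown here alone, whether a simple amine or a longer chain on that nitrogen would also stay within the scatter of compound 2 remains open. So does whether any group at this place can shift the number.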